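Notes on compound 4 following compound 2

A few compounds are considered here, and "the series" means these few. Any claim that something is new, unique, unknown or untested is made for them only; others in the source may bear on it.

Compound 1 `CC(C)n1c(/C=C2/C(=O)Nc3ccc(F)cc32)nc2ccccc21` in a functional assay on A549 cells (Homo sapiens) for cytotoxicity, read by MTT assay, with a stated time of 48 h (on this read-out higher numbers stand for weaker inhibition and lower numbers for stronger inhibition), gives 28500 nM.
Compound 3 `Cn1c(/C=C2/C(=O)Nc3ccc(F)cc32)nc2ccccc21` in this assay gives 34600 nM.
Compound 2 `CCn1c(/C=C2/C(=O)Nc3ccc(C)cc32)nc2ccccc21` reaches only the limit of this assay, reported as > 50000 nM.

Compound 2 therefore stands at the limit of > 50000 nM in this assay, at which 1 of the 3 values shown sits, and carries no number of its own. Compound 4 `CCn1c(/C=C2/C(=O)Nc3ccc([N+](=O)[O-])cc32)nc2ccccc21` differs from it by nitro in place of methyl on an aromatic carbon. Within the data shown here, the only measured step, a 1.2-fold higher number from compound 1 to compound 3 (0.08 log units; within the scatter), concerns the group on the aromatic nitrogen and says nothing about the change from compound 2 to compound 4. Compounds 1 and 3, which carry fluorine where compound 2 carries methyl, both return numbers rather than a limit. Among the measured compounds shown here, no measured step covers nitro. The expected step of an at least 2.0-fold lower number from compound 2 to compound 4 (0.30 log units; that floor lies within the scatter) is a modest move to a lower number, with a limit still possible. Compound 4 is estimated at 25000 nM, range 7000 nM to 50000 nM.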

Compound 4, half-maximal inhibitory concentration: > 50000 nM
Compound 4: only a limit was reported; the forecaster's own chance of this, stated with the estimate: 30%; middle value at least 2.0-fold (0.30 log units) from the limit.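

In this assay compound 4 gives only a limit, > 50000 nM, and compound 2 likewise gives only a limit, so no step can be read between them. The compounds shown leave open how nitro compares with methyl on this aromatic carbon.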